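This account rests on a few compounds, and the source may have more. Where it says the series, first, only, none or still open, it means among the compounds named here.

Measured compounds:
compound 1 `C/N=C(/NC#N)NCCCn1nc(-c2ccccc2)ccc1=O`: 40.5%
compound 2 `CC(C)(C)/N=C(\S)NCCCCn1nc(-c2ccccc2)ccc1=O`: 33.6%

In a functional assay on the whole organism with Rattus norvegicus as the target, at a dose of 100 mg/kg (on this read-out higher numbers stand for more inhibition at the one dose given (going by the name of the read-out) and lower numbers for less inhibition), compound 1 gives 40.5%. In this assay, among the compounds with values here, compound 2 gives 33.6%; of the two numbers this is the one nearest to compound 1, and the gap between them lies within the usual scatter, so the two compounds are not told apart by this read-out. Within the data shown here, no pair of measured compounds differs in one place only, so the size of any single structural step is not known from the data.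

Compound 3 `C/N=C(\S)N(C)CCCCn1nc(-c2ccccc2)ccc1=O` is not yet measured. It differs from compound 2 as follows: a group of 6 heavy atoms (3 carbon, 2 nitrogen, 1 sulfur; no ring) in place of a group of 8 heavy atoms (5 carbon, 2 nitrogen, 1 sulfur; no ring), on a saturated chain carbon, four bonds along the chain from an aromatic nitrogen. Among the measured compounds shown here, with no comparable step available, the expectation rests only on the two measured numbers. The expected step is a number 1.6 percentage points lower from compound 2 to compound 3 (within the scatter), small and not beyond the scatter in either direction. Compound 3 is expected to give 32% in this assay, with a range from 15% to 50%.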

Compound 3, a percentage reported as inhibition, in the whole organism at one dose (the size of the read-out at that dose, not a potency): 17.5%
For compound 3 the middle estimate is 14.5 percentage points above the measured one; the measured number falls inside the stated range.
By their numbers in this assay, from the lowest: compound 3; then compounds 2 and 1 (each within the scatter of the next).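

Within this assay, the group on the saturated chain carbon, four bonds along the chain from an aromatic nitrogen, now proves able to move the number: the group of 6 heavy atoms with 1 hydrogen-bond donor in place of the group of 8 heavy atoms with 2 hydrogen-bond donors gives a number 16.1 percentage points lower from compound 2 to compound 3 (beyond the scatter). Within the data shown here, the other step, a number 23 percentage points lower from compound 1 to compound 3 (beyond the scatter), also lies beyond the scatter, so compound 3 is the first compound this read-out separates from the others, whereas compound 1 and compound 2 could not be told apart. Nothing measured here accounts for the loss.

Among these compounds, the single step does not show whether the lost atoms or the lost hydrogen-bond donor carries the change. It also leaves open whether an amine, a carboxylic acid or a longer chain at this place would hold the number at the level of compound 2.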